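A few compounds are considered here, and "the series" means these few. Any claim that something is new, unique, unknown or untested is made for them only; others in the source may bear on it.

Measured in a functional assay on MCF7 cells (Homo sapiens) for antiproliferative activity, read by MTT assay, with a stated time of 48 h; on this read-out lower numbers stand for stronger inhibition and higher numbers for weaker inhibition:

- Compound 1 `Fc1ccc(-c2nn(-c3ccccc3)cc2-c2nc3cc(Cl)ccc3[nH]2)cc1`: 2230 nM
- Compound 2 `Fc1ccc(-c2nn(-c3ccccc3)cc2-c2nc3cc(Br)ccc3[nH]2)cc1`: 3210 nM
- Compound 3 `Fc1ccc(-c2nn(-c3ccccc3)cc2-c2nc3cc(C(F)(F)F)ccc3[nH]2)cc1`: 2130 nM

These three compounds differ only in one group, which is chloro, bromo or trifluoromethyl. Compound 3, at 2130 nM, stands level with the other two, since its gaps to both lie within the scatter of repeated measurements.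

The next compound, compound 4 `FC(F)(F)c1ccc2[nH]c(-c3cn(-c4ccccc4)nc3-c3ccc(Cl)cc3)nc2c1`, changes a different place in the molecule. Its difference from compound 3 is chloro in place of fluoro on an aromatic carbon. This is chloro in place of fluoro on an aromatic carbon, para to a large group, turning 4-fluorophenyl into 4-chlorophenyl.

Among the compounds with values here, no measured step touches this place, so the evidence is indirect. The closest guide is the set of swaps elsewhere in the molecule: a 1.4-fold higher number from compound 1 to compound 2 (0.16 log units; within the scatter), a 1.0-fold lower number from compound 1 to compound 3 (0.02 log units; within the scatter) and a 1.5-fold lower number from compound 2 to compound 3 (0.18 log units; within the scatter). None of these moved the number in this assay beyond the scatter. The data give no direction for the new swap, and a surprise at an untested place remains possible, so the range is kept wide.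

The expected change is a 1.0-fold higher number from compound 3 to compound 4 (0.01 log units; within the scatter), which would be no step beyond the scatter.

For compound 4 the estimated value is 2200 nM, with an expected range from 1000 nM to 4500 nM.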

Compound 4, half-maximal inhibitory concentration: 4210 nM
Compound 4: middle estimate off by 1.9-fold (0.28 log units), on the low side; the measured number falls inside the stated range.
By their numbers in this assay, from the lowest: compounds 3, 1, 2 and 4 (each within the scatter of the next).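

Within the data shown here, this is the first measured change at a new place in the molecule, on a six-membered aromatic ring of carbon only, para to a large group, whereas the earlier steps all concerned the chloro, bromo and trifluoromethyl place. In this assay, turning 4-fluorophenyl into 4-chlorophenyl gives a 2.0-fold higher number from compound 3 to compound 4 (0.30 log units; within the scatter) and so cannot be told apart from the spread of repeated measurements, although it stands at the very edge of that spread. This place therefore joins the first one in showing no clear step so far, but only one swap, between two halogens, speaks for it, and nothing shown here offers an explanation for the size of the step.

From the compounds shown here alone, it remains open whether a group of a different kind at this place, such as an amine, a carboxylic acid or a longer chain, would move the number beyond the scatter. It is also open whether the 4-chlorophenyl group would give a similar result alongside chloro or bromo at the other place, where only the pairing with trifluoromethyl is shown.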